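Sulfamoylurea piperidine amides: heteroaryl swap at the amide carbonyl

The source may hold more compounds than are shown below. What is called first, only, known or untested is meant among the compounds shown, and "the series" means these compounds.

Three members of the series have a reading in a functional assay on the whole organism (blood) with Rattus norvegicus as the target, with stated times of 24 h and 1 h, at a dose of 5 mg/kg by the intraperitoneal route; a higher number here means a stronger effect of the compound at the dose given, a lower number a weaker effect. Compound 1 `COc1ccc(Cl)cc1C(=O)NCC1CCN(S(=O)(=O)NC(=O)NC2CCCCC2)CC1` gives 20% in this assay. Compound 2 `CCCNC(=O)NS(=O)(=O)N1CCC(CCNC(=O)c2cc(Cl)ccc2OC)CC1` gives 11%. Compound 3 `Cc1ncsc1C(=O)NCCC1CCN(S(=O)(=O)NC(=O)NC[C@@H]2C[C@@H]3C=C[C@@H]2C3)CC1` gives 11%, a number level with that of compound 2 at the digits shown, and within the scatter of the number for compound 1, so that the three readings cannot be told apart. No pair among these three differs in one place only, so no single step has been measured in this assay.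

Compound 4 `O=C(NC[C@@H]1C[C@@H]2C=C[C@@H]1C2)NS(=O)(=O)N1CCC(CCNC(=O)c2cccc3cccnc23)CC1` is not yet measured. It differs from compound 3 by quinolin-8-yl in place of 4-methyl-1,3-thiazol-5-yl on a carbonyl carbon. Among the measured compounds shown here, no measured pair isolates a swap of the aryl group on this carbonyl, so the direction of the step is open. With all three known readings in this assay sitting low and within the scatter of each other, the estimated step from compound 3 to compound 4 is a number 4 percentage points higher from compound 3 to compound 4 (within the scatter), that is, none beyond the scatter in either direction. Compound 4 is therefore expected to give about 15% in this assay, with a range from 3% to 32%.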

Compound 4, a percentage reported as activity, at one dose (the size of the read-out at that dose, not a potency): 34%
The estimate for compound 4 lay 19 percentage points below the measured number; measured number above the stated range.
By their numbers in this assay, from the lowest: compounds 2, 3 and 1 (each within the scatter of the next); then compound 4.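

In this assay, among the compounds shown here, the group on this carbonyl carbon can move the read-out: quinolin-8-yl in place of 4-methyl-1,3-thiazol-5-yl gives a number 23 percentage points higher from compound 3 to compound 4 (beyond the scatter), the only single-place change available so far. The change replaces one five-membered aromatic ring with two six-membered aromatic rings and raises the group from 6 to 10 heavy atoms, while removing the sulfur, so several differences travel together in this one step. Nothing at hand explains the gain in the read-out.

Going by these compounds, it remains open which of these differences carries the step; naphthalen-1-yl or plain phenyl on the same carbonyl would begin to separate ring number from the ring nitrogen. On these data alone, whether the step holds with a cyclohexyl group on the urea also remains open.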